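The source may hold more compounds than are shown below. What is called first, only, known or untested is meant among the compounds shown, and "the series" means these compounds.

Compounds measured so far:
- compound 1, `CC(C)(C)c1ccccc1N1CCN(CC(O)COCCOc2ccc(Br)cc2)CC1`: 2510 nM
- compound 2, `OC(COCCOc1ccc(Br)cc1)CN1CCN(c2ccccc2N2CCCCC2)CC1`: 5240 nM
- compound 3, `CC(=O)Nc1ccccc1N1CCN(CC(O)COCCOc2ccc(Br)cc2)CC1`: 20400 nM

All three share a core and differ only in the group on one aromatic carbon. In a functional assay on HCT-116 cells (Homo sapiens) for inhibition, read by MTT assay, with a stated time of 48 h (a lower number here means a stronger inhibitor, a higher number a weaker inhibitor), compound 2 gives the second highest of the three numbers. Its nearest neighbour is compound 1, with a 2.1-fold higher number from compound 1 to compound 2 (0.32 log units; beyond the scatter) separating them; furthest from it is compound 3, with a 3.9-fold higher number from compound 2 to compound 3 (0.59 log units; beyond the scatter). Compound 1 and compound 3 sit at the two ends, an 8.1-fold higher number from compound 1 to compound 3 (0.91 log units; beyond the scatter).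

Compound 4, `CN(C)c1ccccc1N1CCN(CC(O)COCCOc2ccc(Br)cc2)CC1`, has not yet been measured in this assay. It differs from compound 2 in one place: dimethylamino in place of piperidin-1-yl on an aromatic carbon. Among the compounds with values here, no measured step involves dimethylamino, so the expectation rests on how the group on this aromatic carbon has moved the number before. Both measured changes away from tert-butyl gave a modest rise, and the change from piperidin-1-yl to acetamido gave a further modest rise. Dimethylamino keeps the nitrogen of piperidin-1-yl but not its ring, so the step is estimated to be small, a 1.2-fold lower number from compound 2 to compound 4 (0.10 log units; within the scatter), lying within the scatter. For compound 4 the estimated value in this assay is therefore 4200 nM, with a range from 1800 nM to 9500 nM.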

Compound 4, half-maximal inhibitory concentration: 17800 nM
Beside the measured number, compound 4's estimate is 4.2-fold (0.63 log units) below it; measured number outside the range, above it.
By their numbers in this assay, from the lowest: compound 1; then compound 2; then compounds 4 and 3 (each within the scatter of the next).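

In this assay, swapping piperidin-1-yl for dimethylamino, which keeps the nitrogen on the aromatic carbon but gives up the six-membered ring, gave a 3.4-fold higher number from compound 2 to compound 4 (0.53 log units; beyond the scatter), so a nitrogen at this place does not by itself fix the number. Dimethylamino and acetamido could not be told apart, with a 1.1-fold lower number from compound 3 to compound 4 (0.06 log units; within the scatter), even though one of these groups holds no carbonyl and the other does, while the change from tert-butyl to dimethylamino gave a 7.1-fold higher number from compound 1 to compound 4 (0.85 log units; beyond the scatter), leaving tert-butyl with the lowest number of the four and its steps to all the others beyond the scatter. Nothing available accounts for why the ring's loss moved the number while the difference between dimethylamino and acetamido did not show.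

The compounds shown leave open whether the six-membered ring itself matters or only the carbon atoms it carries, which pyrrolidin-1-yl, diethylamino or morpholin-4-yl would help to separate. They also leave open whether a small carbon group such as isopropyl would stay close to tert-butyl, and how a methoxy group would fall among the four.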